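The compounds below may be only part of what the source reports. "The series", "measured", "known", "first", "only" and "open" are said of these compounds alone.

- Compound 1 `NC1CCc2nc(-c3ccncc3)nc(Nc3ccc(F)cc3)c2C1`: > 250000 nM, a limit of the assay
- Compound 2 `NC1CCc2nc(-c3ccncc3)nc(Nc3cccc(F)c3)c2C1`: 126000 nM

Among the measured compounds shown here, in a physicochemical assay for solubility, read by HPLC, in phosphate buffer, measured as kinetic solubility, with a stated time of 24 h, at pH 7.4 (a lower number here means a less soluble compound, a higher number a more soluble compound), compound 2 holds the only actual number so far, 126000 nM. The other reading is a limit and not a number: compound 1 stands at the limit of > 250000 nM in this assay, at which 1 of the 2 values shown sits.

Compound 3 `CN(C)c1ccc(Nc2nc(-c3ccncc3)nc3c2CC(N)CC3)cc1` has not been measured. It carries 4-(dimethylamino)phenyl in place of 3-fluorophenyl on a nitrogen on an aromatic ring.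

For the measured compounds named here, one measured step bears on this, a change at the same place: an at least 1.9-fold lower number from compound 1 to compound 2 (0.29 log units; that floor lies within the scatter). That step only moved the fluorine, whereas here the whole group is replaced, so the guide is thin. No change beyond the scatter is therefore expected, though with wide uncertainty. The expected size is a 1.2-fold lower number from compound 2 to compound 3 (0.08 log units; within the scatter). For compound 3 the estimate is 105000 nM, with an expected range from 35000 nM to 250000 nM.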

Compound 3, solubility: > 250000 nM
Compound 3: only a limit was reported (the forecaster's own chance of this, stated with the estimate: 15%); at least 2.3-fold (0.37 log units) between middle value and limit.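

In this assay the change from 3-fluorophenyl to 4-(dimethylamino)phenyl on the nitrogen gives an at least 1.9-fold higher number from compound 2 to compound 3 (0.29 log units; that floor lies within the scatter) with no fall in the number. From the compounds shown here alone, the reading of compound 3 is a limit and not a number, so the true size of this step stays unknown, but the position clearly takes a whole new group with a nitrogen in it, which moving the fluorine alone could not show. The step from compound 1 to compound 3 cannot be read, and the top of the scale is what hides it: the limit of > 250000 nM in this assay, at which 2 of the 3 values shown sit.

Still open, going by these compounds, is whether any group at this place brings the number down beyond the scatter. A carboxylic acid on the aromatic ring, or a morpholine in place of dimethylamino, would test how far this tolerance reaches.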